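A few compounds are considered here, and "the series" means these few. Any claim that something is new, unique, unknown or untested is made for them only; others in the source may bear on it.

Compound 1 `Cc1ccc2c(c1C)CN(C(=O)N(C)C)CC2c1ccccc1` is the reference point: in a functional assay on A2780 cells (Homo sapiens) for antiproliferative activity (on this read-out higher numbers stand for weaker inhibition and lower numbers for stronger inhibition), compound 1 gives 1200 nM. On these data alone, compound 2 `Cc1ccc2c(c1C)CN(C(=O)N(C)C)CC2c1ccc(O)cc1` differs from compound 1 in the aryl group attached to the saturated ring carbon, yet in this assay compound 2 gives "not determined" (no result reported), so compound 2 stands without a number and its own potency is unknown. Compound 3 `Cc1ccc2c(c1C)CN(C(=O)N(C)C)CC2c1cccc(Cl)c1` is the next member, not yet tested in this assay. The change from compound 2 to compound 3 is 3-chlorophenyl in place of 4-hydroxyphenyl on a saturated ring carbon. Because compound 2 has no measured value, the size and direction of the step to compound 3 in this assay cannot be judged from compound 2 itself; what can be said rests on compound 1 and its value of 1200 nM, a nearby analogue carrying plain phenyl at the same place. On that basis, compound 3 is expected to give about 800 nM in this assay, with a likely range from 250 nM to 2500 nM.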

Compound 3, half-maximal inhibitory concentration: 3020 nM
Beside the measured number, compound 3's estimate is 3.8-fold (0.58 log units) below it, outside the stated range (above it).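

In this assay, chloro in place of hydrogen on an aromatic carbon gives a 2.5-fold higher number from compound 1 to compound 3 (0.40 log units; beyond the scatter), a modest loss of inhibition that goes beyond the usual scatter. This shows that the aryl group on the saturated ring carbon responds to even a small change, and that 3-chlorophenyl does not improve on plain phenyl here. The step between compound 2 and compound 3 cannot be read, and nothing shown explains the loss seen with the chloro group.

Still open, on these data alone, is whether this loss belongs to chlorine itself or to its place on the phenyl ring, a question that 4-chlorophenyl, 3-methoxyphenyl or 3-aminophenyl at the same carbon could help to settle. As far as these compounds go, the effect of the 4-hydroxyphenyl group of compound 2 in this assay also remains unknown.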